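This account rests on a few compounds, and the source may have more. Where it says the series, first, only, none or still open, it means among the compounds named here.

Measured so far in an ADME assay on NIH3T3 cells (Mus musculus) for cytotoxicity, read by neutral red uptake, with a stated time of 48 h; on this read-out higher numbers stand for lower toxicity in this test and lower numbers for higher toxicity in this test

compound 1 `CCCCCCCC/C=C\c1c(C)nc(C)c(/C=C\CCCCCCCC)c1C` gives "not determined" (no result reported)
compound 2 `CCCCCCCCCCc1c(C)c(CCCCCCCCCC)c2[n+](c1C)CCC2` gives 2.8 uM
compound 3 `CCCCCCCC/C=C\c1c(C)c(/C=C\CCCCCCCC)c2[n+](c1C)CCC2` gives 22.7 uM

Compound 2 (2.8 uM) holds the lower of the two numbers available. Compound 3 (22.7 uM) is the nearest, higher by more than the scatter, while compound 1 has no number to compare.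

Compound 4 `CCCCCCCCCCc1c(C)cc(C)[n+]2c1CCC2` has not yet been measured in this assay. It departs from compound 2 by hydrogen in place of decyl on an aromatic carbon.

Going by the values given here, no measured pair differs in only one place, so the size of this step has no direct precedent. The gap between compound 2 (2.8 uM) and compound 3 (22.7 uM) offers only a rough guide to how far numbers can spread in this small set. A rise beyond the scatter is expected, pointing to lower toxicity in this test, though the uncertainty is wide.

The estimate corresponds to an expected rise (a 5.4-fold higher number from compound 2 to compound 4 (0.73 log units; beyond the scatter)).

Compound 4 is estimated at 15 uM (expected range 4 uM to 60 uM).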

Compound 4, half-maximal toxic concentration: 3.2 uM
Compound 4: middle estimate off by 4.7-fold (0.67 log units), on the high side, outside the stated range (below it).
By their numbers in this assay, from the lowest: compounds 2 and 4 (each within the scatter of the next); then compound 3.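

In this assay, hydrogen in place of decyl on the aromatic carbon ortho to two methyl groups gives a 1.1-fold higher number from compound 2 to compound 4 (0.06 log units; within the scatter) and so leaves the two compounds indistinguishable on this read-out. The decyl group at this position, with its 10 carbon atoms, therefore makes no measurable contribution here, and compound 4, with a single decyl group, cannot be separated from compound 2, with two. No measured property of these compounds accounts for this result.

Still open, as far as these compounds go, is whether this position stays as undemanding with groups other than decyl or hydrogen, such as a butyl chain, an amine or a carboxylic acid. Also open, from the compounds shown here alone, is whether hydrogen at this carbon would have as little effect on compound 3, which carries different chains.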